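Working notes: a third methoxy group in the series

A few compounds are considered here, and "the series" means these few. Any claim that something is new, unique, unknown or untested is made for them only; others in the source may bear on it.

Measured so far:
compound 1 `COc1cc(-c2cc(/C=C/C(=O)c3ccc(N)cc3)[nH]n2)cc(OC)c1OC` — 88% in a functional assay on NCI-H226 cells (Homo sapiens) for cytotoxicity, read by sulforhodamine B assay, with a stated time of 48 h, tested at 1 uM; on this read-out lower numbers stand for a stronger effect and higher numbers for a weaker effect at the one concentration tested
compound 2 `COc1ccc(C(=O)/C=C/c2cc(-c3cc(OC)c(OC)c(OC)c3)n[nH]2)cc1OC` — 89% in this assay

For the measured compounds named here, compound 2 holds the highest of the two numbers in this assay, but the only measured step, a number 1 percentage points higher from compound 1 to compound 2 (within the scatter), stays within the scatter, so the two compounds read alike. Compound 3 `COc1cc(C(=O)/C=C/c2cc(-c3cc(OC)c(OC)c(OC)c3)n[nH]2)cc(OC)c1OC` differs from compound 2 by methoxy in place of hydrogen on an aromatic carbon. Going by the values given here, no measured step touches a methoxy in place of hydrogen on an aromatic carbon; the one step known concerns another group and is flat. The step from compound 2 to compound 3 is therefore expected to be a number 3 percentage points lower from compound 2 to compound 3 (within the scatter), not beyond the scatter. Compound 3 is estimated at 86%, with a range from 70% to 100%.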

Compound 3, a percentage reported as activity, at one concentration (the size of the read-out at that concentration, not a potency): 86%
For compound 3 middle estimate and measured number coincide at the digits printed; low and high end bracket the measured number.
By their numbers in this assay, from the lowest: compounds 3, 1 and 2 (each within the scatter of the next).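

The methoxy in place of hydrogen, on an aromatic carbon ortho to a methoxy group and meta to a large group, comes with a number 3 percentage points lower from compound 2 to compound 3 (within the scatter) in this assay. For the compounds shown here, this is the first reading for a change on this ring, and it shows that the position takes the added methoxy while compound 3 reads alike to compound 2. No supporting data bear on this step.

Going by these compounds, whether an amine or a carboxylic acid at this position would give a step beyond the scatter stays open, as does the effect of a hydroxyl group there.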